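Thiocarbonyl ring swaps in a small amidrazone-thiocarbonyl series

The source may hold more compounds than are shown below. What is called first, only, known or untested is meant among the compounds shown, and "the series" means these compounds.

Measured so far in a functional assay on HeLa cells (Homo sapiens) for cytotoxicity, read by MTT assay, with a stated time of 72 h; a higher number here means a weaker inhibitor, a lower number a stronger inhibitor:
compound 1 `N/C(=N\NC(=S)N1CCOCC1)c1ccccn1` gives 7300 nM
compound 2 `N/C(=N\NC(=S)N1CCCC1)c1ccc(F)cn1` gives 1800 nM
compound 3 `N/C(=N\NC(=S)N1CCSCC1)c1ccc(F)cn1` gives 1700 nM

Compound 3 has the lowest of the three numbers, but compound 2 sits within the scatter of it, so no order between the two is claimed; compound 1, which differs from compound 3 in two places, stands beyond the scatter above both.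

Compound 4 `N/C(=N\NC(=S)N1CCOCC1)c1ccc(F)cn1` is not yet measured. It differs from compound 3 by morpholin-4-yl in place of thiomorpholin-4-yl on a thiocarbonyl carbon.

Within the data shown here, the one measured step at this position, a 1.1-fold lower number from compound 2 to compound 3 (0.02 log units; within the scatter), was within the scatter. A second ring swap on the same thiocarbonyl carbon is therefore expected to move this assay little, if at all, though compound 1 with its morpholin-4-yl ring and 7300 nM leaves some room for a drift to a higher number. For compound 4 the estimate is 2200 nM (range 1000 nM to 5000 nM), an expected step of a 1.3-fold higher number from compound 3 to compound 4 (0.11 log units; within the scatter).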

Compound 4, half-maximal inhibitory concentration: 1700 nM
The estimate for compound 4 lay 1.3-fold (0.11 log units) above the measured number; low and high end bracket the measured number.
By their numbers in this assay, from the lowest: compounds 3, 4 and 2 (each within the scatter of the next); then compound 1.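

In this assay the ring on the thiocarbonyl carbon gives no change at the digits printed from compound 3 to compound 4 (within the scatter) and a 1.1-fold lower number from compound 2 to compound 4 (0.02 log units; within the scatter) with the fluoro group in place, so morpholin-4-yl, thiomorpholin-4-yl and pyrrolidin-1-yl are not told apart here. Among these compounds, with morpholin-4-yl held fixed, fluoro in place of hydrogen gives a 4.3-fold lower number from compound 1 to compound 4 (0.63 log units; beyond the scatter) as the only single change read beyond the scatter. No data here bear on the reason for either result.

Still open, as far as these compounds go, is whether a piperidin-1-yl ring or a dimethylamino group on the thiocarbonyl carbon would stay within the scatter of these rings. Also open, from the compounds shown here alone, is whether chloro or methoxy on the aromatic carbon would give a step like that of fluoro.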